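The source may report more compounds than this note shows. Statements on the series, on what has been measured and on what is new or still open speak of the compounds shown alone.

Two compounds from this series have been run in a functional assay on HepG2 cells (Homo sapiens) for cytotoxicity, read by MTT assay, with a stated time of 48 h; on this read-out higher numbers stand for weaker inhibition and lower numbers for stronger inhibition. Compound 1, `CC(=O)OC[C@H]1O[C@H](NS(N)(=O)=O)C=C[C@@H]1OC(C)=O`, gives 336000000 nM in this assay. Compound 2, `CC(=O)OC[C@H]1O[C@H](NS(=O)(=O)c2ccc(C)cc2)C(OC(C)=O)=C[C@@H]1OC(C)=O`, gives 39200000 nM in this assay, which is the lower of the two numbers; the gap to compound 1 lies beyond the usual scatter, so compound 2 stands as the stronger of the pair on this read-out. The two differ in more than one place, so nothing can be said about which part of the structure carries that gap.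

Compound 3, `CC(=O)OC[C@H]1O[C@H](NS(=O)(=O)c2ccc(C)cc2)C=C[C@@H]1OC(C)=O`, has not yet been measured. It differs from compound 2 in one place only: hydrogen in place of acetoxy on a double-bonded ring carbon. No single change of this kind has been measured here, so the expected size of the step rests on very little. Compound 1, which also lacks this acetoxy group, gives the higher number, but it carries a different sulfonyl substituent, so its value cannot be read as the effect of this change alone.

On balance compound 3 is expected to give 70000000 nM in this assay, within a range from 15000000 nM to 300000000 nM. The step from compound 2 that this estimate implies, a 1.8-fold higher number from compound 2 to compound 3 (0.25 log units; within the scatter), is expected to be a modest loss, possibly no more than the scatter.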

Compound 3, half-maximal inhibitory concentration: 157000000 nM
For compound 3 the middle estimate is 2.2-fold (0.35 log units) below the measured one, and the stated range covers the measured number.
By their numbers in this assay, from the lowest: compound 2; then compound 3; then compound 1.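

For the compounds shown here, putting hydrogen in place of acetoxy on a double-bonded ring carbon gives a 4.0-fold higher number from compound 2 to compound 3 (0.60 log units; beyond the scatter) in this assay, the first reading of a single change at this position, and it shows that the step there lies beyond the scatter, with the acetoxy compound on the stronger side. The other new pair, with 4-methylphenyl in place of amino on a sulfonyl sulfur, gives a 2.1-fold lower number from compound 1 to compound 3 (0.33 log units; beyond the scatter) and is also beyond the scatter, so the gap between compound 1 and compound 2, which could not be assigned before, now divides into two single changes that both run towards lower numbers, with compound 3 between them. Nothing available here offers a reason for either step.

The compounds shown leave open whether the lower number depends on acetoxy itself or would also appear with another group on that ring carbon, such as hydroxyl, methoxy or a halogen. They also leave open whether the acetoxy step holds when amino sits on the sulfonyl sulfur, and how a longer alkyl chain or a carboxylic acid on the aryl ring of the sulfonyl group would read.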